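The source may hold more compounds than are shown below. What is called first, only, known or untested is meant among the compounds shown, and "the series" means these compounds.

Compound 1 `COc1ncnc2c1c(-c1ccsc1)cn2[C@@H]1O[C@H](CO)[C@@H](O)[C@H]1O`: 430 nM
Compound 2 `Cc1ncnc2c1c(I)cn2[C@@H]1O[C@H](CO)[C@@H](O)[C@H]1O`: 3460 nM
Compound 3 `COc1ncnc2c1c(-c1ccoc1)cn2[C@@H]1O[C@H](CO)[C@@H](O)[C@H]1O`: 290 nM

All three were tested in a functional assay on HepG2 cells (Homo sapiens) for antiproliferative activity, read by XTT assay, with a stated time of 72 h; a lower number here means a stronger inhibitor, a higher number a weaker inhibitor. Compound 3 gives the lowest of the three numbers, but compound 1 lies within the scatter of it, so the two cannot be ranked against each other; compound 2 gives a clearly higher number, beyond the scatter. Going by the values given here, the only single change among the measured compounds is a 1.5-fold lower number from compound 1 to compound 3 (0.17 log units; within the scatter), where one five-membered ring replaces another and the number barely moves.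

Compound 4 `Cc1ncnc2c1c(-c1ccoc1)cn2[C@@H]1O[C@H](CO)[C@@H](O)[C@H]1O` differs from compound 3 in one place: methyl in place of methoxy on an aromatic carbon. Among the compounds with values here, no measured pair isolates this change. Compound 2 also carries a methyl at that place, yet it differs from compound 3 in two places at once, so its higher number cannot be laid at the methyl alone. The step of a 1.5-fold lower number from compound 1 to compound 3 (0.17 log units; within the scatter) concerns the other ring and says nothing about this one. With no direct guide, the expectation for compound 4 is a modest rise in the number, a step of a 1.7-fold higher number from compound 3 to compound 4 (0.24 log units; within the scatter) that may or may not clear the scatter. Compound 4 is therefore estimated at 500 nM, with a likely range from 150 nM to 1800 nM.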

Compound 4, half-maximal inhibitory concentration: 5320 nM
The estimate for compound 4 lay 11-fold (1.03 log units) below the measured number; measured number above the stated range.
By their numbers in this assay, from the lowest: compounds 3 and 1 (each within the scatter of the next); then compounds 2 and 4 (each within the scatter of the next).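

In this assay, methyl in place of methoxy on this aromatic carbon, next to the ring nitrogen, gives an 18-fold higher number from compound 3 to compound 4 (1.26 log units; beyond the scatter), so this one change at this place is enough to move the number by a large step, which compound 2 could not show while it differed from compound 3 in two places at once. With methyl held at this place, furan-3-yl in place of iodo gives a 1.5-fold higher number from compound 2 to compound 4 (0.19 log units; within the scatter), so these two groups cannot be told apart here, just as thiophen-3-yl and furan-3-yl could not be told apart with methoxy in place. The data shown offer no measurement that explains the large step at this place.

As far as these compounds go, it remains open whether methoxy is unusual here or whether other groups at this place, such as ethoxy, an amine or a hydroxyl, would keep the number low. From the compounds shown here alone, it is also open whether iodo with methoxy at this place would give the same low number as the two five-membered rings do.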